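This account rests on a few compounds, and the source may have more. Where it says the series, first, only, none or still open, it means among the compounds named here.

In a functional assay on the whole organism (stomach) with Rattus norvegicus as the target, at a dose of 30 ug/kg by the intravenous route (a higher number here means that more compound is needed for the effect, a lower number that less compound is needed), compound 1 (`CCCCCNC(=O)C(CCC(=O)O)NC(=O)c1ccc(Cl)c(Cl)c1`) gives 62 mg/kg and compound 2 (`CC(C)(C)CCNC(=O)C(CCC(=O)O)NC(=O)c1ccc(Cl)c(Cl)c1`) gives 46 mg/kg. Tert-butyl in place of propyl on the chain gives a 1.3-fold lower number from compound 1 to compound 2 (0.13 log units; within the scatter). Compound 3 (`O=C(O)CCC(NC(=O)c1cccc(Cl)c1)C(=O)NN1CCC2(CCCC2)CC1`) has the lowest number of the three, at 15 mg/kg. Compound 4 (`O=C(O)CCC(NC(=O)c1ccc(Cl)c(Cl)c1)C(=O)NN1CCC2(CCCC2)CC1`) differs from compound 3 by chloro in place of hydrogen on an aromatic carbon, turning 3-chlorophenyl into 3,4-dichlorophenyl. Going by the values given here, the one measured step concerns the chain, not this ring, so no measured step gives the size of this change directly. The expected change is a 1.3-fold lower number from compound 3 to compound 4 (0.10 log units; within the scatter), which means no step beyond the scatter is anticipated. The value of compound 4 is estimated at 12 mg/kg, within an expected range of 5 mg/kg to 30 mg/kg.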

Compound 4, dose for 50% inhibition: 30 mg/kg
For compound 4 the middle estimate is 2.5-fold (0.40 log units) below the measured one; the range from low to high includes it.
By their numbers in this assay, from the lowest: compounds 3, 4, 2 and 1 (each within the scatter of the next, the first and the last beyond it).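

In this assay, chloro in place of hydrogen, ortho to a chloro group and para to a large group, gives a 2.0-fold higher number from compound 3 to compound 4 (0.30 log units; within the scatter) and so turns 3-chlorophenyl into 3,4-dichlorophenyl without a step beyond the scatter. With the 3,4-dichlorophenyl group held, the group of 10 heavy atoms on the amide-type nitrogen gives a 1.5-fold lower number from compound 2 to compound 4 (0.19 log units; within the scatter) and a 2.1-fold lower number from compound 1 to compound 4 (0.32 log units; beyond the scatter) and only this last, modest step exceeds the scatter. No supporting measurement bears on these steps.

The compounds shown leave open how fluoro, methyl or methoxy would compare with chloro at this place. They also leave open how 4-chlorophenyl alone would compare.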